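Cytotoxicity notes: succinimide in place of methylpiperazine

The source may hold more compounds than are shown below. What is called first, only, known or untested is meant among the compounds shown, and "the series" means these compounds.

Compound 1 `CN1CCN(C[C@H]2CN(c3ccc(-n4cc(-c5ccccn5)cn4)c(F)c3)C(=O)O2)CC1` is the reference point of this set. Among the measured compounds shown here, in an ADME assay on L02 cells (Homo sapiens) for cytotoxicity, read by MTT assay, with a stated time of 48 h (on this read-out lower numbers stand for stronger inhibition and higher numbers for weaker inhibition), compound 1 gives 70 ug/mL, the only plain number obtained so far. Compound 2 `O=C1O[C@@H](CN2CCC(c3ccc(F)cc3)CC2)CN1c1ccc(-n2cc(-c3ccccn3)cn2)c(F)c1`, a differently substituted analogue on the shared core, reaches only a limit of the assay: in this assay compound 2 gives > 400 ug/mL. For the measured compounds named here, the one other value is thus (the limit of > 400 ug/mL in this assay, at which 1 of the 2 values shown sits), and no step between measured compounds can be drawn from it.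

Compound 3 `O=C1CCC(=O)N1C[C@H]1CN(c2ccc(-n3cc(-c4ccccn4)cn3)c(F)c2)C(=O)O1` differs from compound 1 in one place: 2,5-dioxopyrrolidin-1-yl in place of 4-methylpiperazin-1-yl on a saturated chain carbon bound to a saturated ring carbon. Going by the values given here, with no measured step to lean on, the size of the change in this assay is open; the expectation is for a shift toward weaker inhibition, though one that may not exceed the usual scatter. Compound 3 is therefore estimated at 150 ug/mL, with a range from 45 ug/mL to 400 ug/mL. This corresponds to an expected step of a 2.1-fold higher number from compound 1 to compound 3 (0.33 log units; beyond the scatter).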

Compound 3, half-maximal inhibitory concentration: > 400 ug/mL
Compound 3: no number, only a limit; the forecaster's own chance of this, stated with the estimate: 30%; middle value at least 2.6-fold (0.42 log units) away from the limit.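

In this assay, among the compounds shown here, 2,5-dioxopyrrolidin-1-yl in place of 4-methylpiperazin-1-yl on a saturated chain carbon bound to a saturated ring carbon gives an at least 5.7-fold higher number from compound 1 to compound 3 (0.75 log units; beyond the scatter), the first step that can be read. The read-out at this position therefore depends on the group it carries, even though both groups have the same heavy-atom count, the same hydrogen-bond donor and acceptor counts and no net charge. The step remains a lower bound because compound 3 stands at a limit of the assay: the limit of > 400 ug/mL in this assay, at which 2 of the 3 values shown sit.

On these data alone, it remains open whether the step follows the two added carbonyls, the five-membered ring or the loss of the second ring nitrogen. Morpholin-4-yl or an open-chain amide at this position could help separate these features if either gave a plain number.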